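A few compounds are considered here, and "the series" means these few. Any claim that something is new, unique, unknown or untested is made for them only; others in the source may bear on it.

Three compounds were examined in a functional assay on A549 cells (Homo sapiens) for inhibition, read by MTT assay, with a stated time of 24 h; a lower number here means a stronger inhibitor, a higher number a weaker inhibitor. Compound 1 `[O-]/[N+](=C\c1cn(-c2ccc(C(F)(F)F)cc2)nn1)Cc1ccccc1` reaches only the limit of this assay, > 100000 nM. Compound 2 `CCCCCCCCn1cc(/C=[N+](\[O-])Cc2ccccc2)nn1` likewise gives only a limit, > 100000 nM. Compound 3 `CC(C)(C)/[N+]([O-])=C/c1cn(-c2ccc(C(F)(F)F)cc2)nn1` gives a number in this assay, 43600 nM. The change that separates compound 1 from compound 3 is tert-butyl in place of benzyl on a double-bonded nitrogen, and it made an at least 2.2-fold lower number from compound 1 to compound 3 (0.36 log units; beyond the scatter). Because (the limit of > 100000 nM in this assay, at which 2 of the 3 values shown sit), the step from compound 1 to compound 3 can be stated only as a bound. The difference between the core of compound 1 and the core of compound 2 is not broken down here. Compound 4 `CCCCCCCCn1cc(/C=[N+](\[O-])C(C)(C)C)nn1` has not yet been measured; it arises from compound 2 by the same change, (tert-butyl in place of benzyl on a double-bonded nitrogen), at the same place. Among the measured compounds shown here, for compound 4 the step from its parent is expected to be about an at least 1.4-fold lower number from compound 2 to compound 4 (0.15 log units; that floor lies within the scatter), since in this assay the only guide is what compound 1 and compound 3 showed. Compound 4 is therefore estimated at 70000 nM, expected to fall between 25000 nM and 200000 nM, with a real chance that this assay again reports only a limit.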

Compound 4, half-maximal inhibitory concentration: 31300 nM
The estimate for compound 4 lay 2.2-fold (0.35 log units) above the measured number; the range from low to high includes it.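

In this assay, putting tert-butyl in place of benzyl on the double-bonded nitrogen made an at least 3.1-fold lower number from compound 2 to compound 4 (0.50 log units; beyond the scatter), so the change lowered the number on the core of compound 2 as it had on the core of compound 1. Within these two pairs, the direction of the change therefore carried from one core to the other, and the two steps compare as follows: the same change on two cores in this assay, an at least 2.2-fold lower number (0.36 log units; beyond the scatter) from compound 1 to compound 3 and an at least 3.1-fold lower number (0.50 log units; beyond the scatter) from compound 2 to compound 4; the limit leaves it open whether they differ The true size of the change on either core remains unknown, and so does any difference in its size between the cores, because each step starts from a benzyl compound that reached only a limit: the limit of > 100000 nM in this assay, at which 2 of the 4 values shown sit.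

The compounds shown leave open whether an isopropyl group or a cyclohexyl group on that nitrogen would give a number like those seen with tert-butyl. They also leave open how the number would respond if an amine or a carboxylic acid were carried on the part of the core that differs between the two pairs.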